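The source may report more compounds than this note shows. Statements on the series, on what has been measured and on what is new or still open speak of the compounds shown alone.

Compound 1 `CCOc1ccccc1-c1nnc(SCCn2c([N+](=O)[O-])cnc2C)o1` and compound 2 `Cc1ncc([N+](=O)[O-])n1CCSc1nnc(-c2ccccc2O)o1` share one core. In a functional assay on SGC-7901 cells (Homo sapiens) for cytotoxicity, read by MTT assay, with a stated time of 48 h (on this read-out higher numbers stand for weaker inhibition and lower numbers for stronger inhibition), compound 1 gives 30300 nM, and compound 2 gives 30500 nM, so compound 2 sits alongside compound 1 with the two numbers inside the scatter. Going by the values given here, the only measured step, a 1.0-fold higher number from compound 1 to compound 2 (0.00 log units; within the scatter), alters a group on an oxygen. Compound 3 `Cc1ncc([N+](=O)[O-])n1CCSc1nnc(-c2ccnc(Cl)c2)o1` carries 2-chloropyridin-4-yl in place of 2-hydroxyphenyl on an aromatic carbon. Among the compounds with values here, no measured step covers such an exchange of one ring for another, so nothing here predicts a shift, and the step from compound 2 to compound 3 is expected to stay within the scatter: a 1.0-fold lower number from compound 2 to compound 3 (0.01 log units; within the scatter). Compound 3 is estimated at 30000 nM, with a range from 10000 nM to 90000 nM.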

Compound 3, half-maximal inhibitory concentration: 32300 nM
Compound 3: the middle estimate sits 1.1-fold (0.03 log units) below what was measured; measured number inside the range.
By their numbers in this assay, from the lowest: compounds 1, 2 and 3 (each within the scatter of the next).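

At this place on the five-membered aromatic ring, putting 2-chloropyridin-4-yl in place of 2-hydroxyphenyl gives a 1.1-fold higher number from compound 2 to compound 3 (0.02 log units; within the scatter) in this assay. Where the earlier step altered only a group on an oxygen, this one replaces the whole aromatic ring and removes the hydrogen-bond donor, yet the numbers remain within the scatter. No supporting data explain this result. From the compounds shown here alone, it remains open whether an amine or a carboxylic acid at this place would give a number beyond the scatter. Going by these compounds, the effect of a longer chain between the shared core's sulfur and nitroimidazole parts also remains open.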